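This account rests on a few compounds, and the source may have more. Where it says the series, first, only, none or still open, it means among the compounds named here.

Compound 1 `NC(=O)c1ccc(O)c2ccccc12`: "not determined" (no result reported)
Compound 2 `Cc1ccc(S(=O)(=O)Nc2ccc(O)c3ccccc23)cc1`: 12000 nM

Among the measured compounds shown here, in an assay on isolated protein for inhibition of histone acetyltransferase KAT2B (Homo sapiens), read by fluorescence, with a stated time of 5 min, in the presence of a further agent that is not named here (a higher number here means a weaker inhibitor, a lower number a stronger inhibitor), compound 2 gives 12000 nM, the only number in this set; for compound 1 no result was reported, so compound 2 has nothing to be compared against. Compound 3 `CS(=O)(=O)Nc1ccc(O)c2ccccc12` is the untested partner. It differs from compound 2 in one place: methyl in place of 4-methylphenyl on a sulfonyl sulfur. With no measured step of this kind in the set, the size of the change can only be judged from the structures: a group of seven heavy atoms with its own ring is replaced by a single carbon, which removes most of what the sulfonamide carried. The expected direction is toward a weaker inhibitor, by a step that is expected to lie somewhat beyond the scatter, a 2.5-fold higher number from compound 2 to compound 3 (0.40 log units; beyond the scatter). Compound 3 is therefore estimated at 30000 nM in this assay, within a range from 10000 nM to 100000 nM.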

Compound 3, half-maximal inhibitory concentration: 3800 nM
Compound 3: middle estimate off by 7.9-fold (0.90 log units), on the high side; the measured number lies below the stated range.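

In this assay, putting methyl in place of 4-methylphenyl on the sulfonyl sulfur gives a 3.2-fold lower number from compound 2 to compound 3 (0.50 log units; beyond the scatter), so the smaller compound is the stronger inhibitor of this pair. The ring of the 4-methylphenyl group is therefore not required for inhibition in this assay, and losing it improves the number rather than worsening it, though this rests on a single pair of compounds. Nothing in the data on hand says why the number falls.

The compounds shown leave open whether the gain holds for other groups on the sulfonyl sulfur, such as ethyl, a longer chain or a phenyl ring without its methyl. They also leave open whether an amine or a carboxylic acid attached to that methyl carbon would move the number further in either direction.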